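Naphthyl in place of methoxyphenyl: an estimate for compound 4

The compounds below may be only part of what the source reports. "The series", "measured", "known", "first", "only" and "open" are said of these compounds alone.

compound 1 `COc1ccc(C2CC(c3ccccc3)=NN2C2=NC(=O)/C(=C3\C(=O)Nc4ccccc43)S2)cc1`: 1620 nM
compound 2 `COc1ccc(C2=NN(C3=NC(=O)/C(=C4\C(=O)Nc5ccccc54)S3)C(c3ccc(OC)cc3)C2)cc1`: 43900 nM
compound 3 `COc1ccc(C2=NN(C3=NC(=O)/C(=C4\C(=O)Nc5ccc(Cl)cc54)S3)C(c3ccc(OC)cc3)C2)cc1`: 200 nM

All three were tested in a functional assay on cells (Cancer cell lines, Homo sapiens) for cytotoxicity, read by sulforhodamine B assay, with a stated time of 48 h; on this read-out higher numbers stand for weaker inhibition of growth and lower numbers for stronger inhibition of growth. On these numbers compound 2 stands highest, which here means the weakest growth inhibition; compound 1 lies nearest to it and compound 3 furthest. Compound 4 `COc1ccc(C2CC(c3ccc4ccccc4c3)=NN2C2=NC(=O)/C(=C3\C(=O)Nc4ccccc43)S2)cc1` differs from compound 2 in one place: naphthalen-2-yl in place of 4-methoxyphenyl on a carbon with a double bond to nitrogen.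

Two measured steps exist. The step of a 220-fold lower number from compound 2 to compound 3 (2.34 log units; beyond the scatter) changes another ring and says nothing about the new group. The step of a 27-fold higher number from compound 1 to compound 2 (1.43 log units; beyond the scatter) concerns the same carbon: there, adding a methoxy to the phenyl weakened growth inhibition strongly. As far as these compounds go, the naphthalen-2-yl group carries no methoxy, so undoing that loss is the expected part; what the second fused ring adds is untested. Compound 4 is therefore expected to show a step of a 29-fold lower number from compound 2 to compound 4 (1.47 log units; beyond the scatter), landing near compound 1. The estimate for compound 4 is 1500 nM, with a range from 300 nM to 8000 nM.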

Compound 4, concentration for 50% growth inhibition: 670 nM
Estimate against measurement, compound 4: 2.2-fold (0.35 log units) above, and the stated range covers the measured number.
By their numbers in this assay, from the lowest: compound 3; then compound 4; then compound 1; then compound 2.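

In this assay, for the compounds shown here, this carbon had so far carried only phenyl and 4-methoxyphenyl, and replacing the latter with naphthalen-2-yl gives a 66-fold lower number from compound 2 to compound 4 (1.82 log units; beyond the scatter) as a large gain in growth inhibition. Set against plain phenyl, the same group gives a 2.4-fold lower number from compound 1 to compound 4 (0.38 log units; beyond the scatter) as a modest gain, so at this carbon a group larger than phenyl can go with stronger growth inhibition, and among these three groups only the 4-methoxyphenyl of compound 2 brings a loss. Why the three groups differ in this way is something no measurement here explains.

As far as these compounds go, it remains open how a carbon-only ring compares with one carrying an amine or a carboxylic acid at this carbon. Also open, from the compounds shown here alone, is whether the chloro on the ring that separates compound 3 from compound 2 would lower the number for compound 4 as well.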